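Methyl for Chlorine on the Benzoyl Arm of Compound 2

This account rests on a few compounds, and the source may have more. Where it says the series, first, only, none or still open, it means among the compounds named here.

Measured in a functional assay on CNE-2 cells (Homo sapiens) for cytotoxicity, read by MTT assay, with a stated time of 72 h; a lower number here means a stronger inhibitor, a higher number a weaker inhibitor:
compound 1 `COc1ccccc1C(=O)NC(=S)NNc1ncnc2ccccc12` gives 15700 nM
compound 2 `O=C(NC(=S)NNc1ncnc2ccccc12)c1ccc(Cl)cc1` gives 1530 nM
compound 3 `O=C(NC(=S)NNc1ncnc2ccccc12)c1ccc(C(F)(F)F)cc1` gives 22500 nM

Compound 2 stands lowest of the three in this assay; the steps of a 10-fold lower number from compound 1 to compound 2 (1.01 log units; beyond the scatter) and a 15-fold higher number from compound 2 to compound 3 (1.17 log units; beyond the scatter) set both other compounds well beyond the scatter from it. Compound 4 `Cc1ccccc1C(=O)NC(=S)NNc1ncnc2ccccc12` differs from compound 2 by 2-methylphenyl in place of 4-chlorophenyl on a carbonyl carbon. The step that bears most closely on this is a 10-fold lower number from compound 1 to compound 2 (1.01 log units; beyond the scatter), since compound 1, like compound 4, carries its substituent in the same place on the phenyl and its number was far higher. The step of a 15-fold higher number from compound 2 to compound 3 (1.17 log units; beyond the scatter) shows that a change on this phenyl can move the number a long way. A large rise in this assay is therefore expected for compound 4, estimated at 12000 nM with a range of 4000 nM to 36000 nM, which means an expected step of a 7.8-fold higher number from compound 2 to compound 4 (0.89 log units; beyond the scatter).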

Compound 4, half-maximal inhibitory concentration: 5460 nM
For compound 4 the middle estimate is 2.2-fold (0.34 log units) above the measured one; low and high end bracket the measured number.
By their numbers in this assay, from the lowest: compound 2; then compound 4; then compounds 1 and 3 (each within the scatter of the next).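

In this assay, the exchange of 4-chlorophenyl for 2-methylphenyl gives a 3.6-fold higher number from compound 2 to compound 4 (0.55 log units; beyond the scatter), so this position tolerates the change with a modest loss rather than a large one. Methyl in place of methoxy gives a 2.9-fold lower number from compound 1 to compound 4 (0.46 log units; beyond the scatter), which shows that a single group on this aromatic ring separates these two compounds beyond the scatter. Nothing available accounts for either step.

On these data alone, compound 4 changes both the group and its place on the phenyl, so the share of each in the step stays open. As far as these compounds go, how an amine or a carboxylic acid on this phenyl would compare also remains open.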